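Cyclohexyl for cyclopropyl on the amine-bound chain carbon

This account rests on a few compounds, and the source may have more. Where it says the series, first, only, none or still open, it means among the compounds named here.

compound 1 `CCCN(C[C@H]1Cc2c(cccc2N2CCNCC2)CN1)[C@H]1CCCc2cccnc21`: in a functional assay on CCRF-CEM cells for agonist activity at C-X-C chemokine receptor type 4 (Homo sapiens), read by calcium flux, with a stated time of 25 min (on this read-out lower numbers stand for an effect already at smaller amounts and higher numbers for an effect only at larger amounts of compound), compound 1 gives > 30000 nM, a limit of the assay
compound 2 `c1cnc2c(c1)CCC[C@@H]2N(CC1CC1)C[C@H]1Cc2c(cccc2N2CCNCC2)CN1`: in this assay compound 2 gives > 30000 nM, again a limit of the assay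
compound 3 `CN(C[C@@H]1Cc2c(cccc2N2CCNCC2)CN1)[C@H]1CCCc2cccnc21`: in this assay compound 3 gives > 30000 nM, also a limit of the assay

Compound 2 stands where every measured member of the series stands, at the limit of > 30000 nM in this assay, at which 3 of the 3 values shown sit. No number for it is known, only the limit. Among the compounds with values here, the one step that can be read off the structures, a step that the two limits leave unreadable from compound 1 to compound 2, gives nothing usable, and no other pair with a single change is present.

Compound 4 `c1cnc2c(c1)CCC[C@@H]2N(CC1CCCCC1)C[C@H]1Cc2c(cccc2N2CCNCC2)CN1` is to be measured in this assay. It differs from compound 2 by cyclohexyl in place of cyclopropyl on a saturated chain carbon bound to an amine nitrogen.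

Within the data shown here, nothing measured here bears on this change: the only step in the set is unreadable, and all three values sit at the limit. The expectation for compound 4 is therefore that the step of a number no higher from compound 2 to compound 4 (the limit leaves the size open) will most likely be unreadable too, with the assay returning a limit again. Should a number appear, compound 4 is estimated at 30000 nM, within a range of 8000 nM to 100000 nM.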

Compound 4, half-maximal effective concentration: > 30000 nM
Compound 4 was reported as a limit; the forecaster's own chance of this, stated with the estimate: 80%; the middle value lies on the limit itself.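

Compound 4 gives > 30000 nM, a limit of the assay and not a number, so no new step can be read from compound 1 or compound 2 to compound 4. The compounds shown leave open whether any substituent on this amine gives a measurable value on the shared core.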